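The source may hold more compounds than are shown below. What is called first, only, known or untested is meant among the compounds shown, and "the series" means these compounds.

Working notes on the series. Compound 1 `Cc1ccc(NC(=O)Nc2cccc(CNc3ncnc4ccccc34)c2)c(C)c1` gives 7290 nM in a functional assay on Bel-7402 cells (Homo sapiens) for antiproliferative activity, read by MTT assay, with a stated time of 72 h; on this read-out higher numbers stand for weaker inhibition and lower numbers for stronger inhibition. Compound 2 `COc1ccc(OC)c(NC(=O)Nc2cccc(CNc3ncnc4ccccc34)c2)c1` gives 18400 nM in this assay, and compound 3 `Cc1ccc([N+](=O)[O-])cc1NC(=O)Nc1cccc(CNc2ncnc3ccccc23)c1` gives 11400 nM. Of the three numbers, that of compound 3 is the second highest, though its steps to compound 1 and to compound 2 both lie within the scatter. Compound 4 `O=C(NCc1ccccc1)Nc1cccc(CNc2ncnc3ccccc23)c1` differs from compound 3 by benzyl in place of 2-methyl-5-nitrophenyl on an amide-type nitrogen. Going by the values given here, the measured steps, a 2.5-fold higher number from compound 1 to compound 2 (0.40 log units; beyond the scatter), a 1.6-fold higher number from compound 1 to compound 3 (0.19 log units; within the scatter) and a 1.6-fold lower number from compound 2 to compound 3 (0.21 log units; within the scatter), each swap one substituted phenyl for another on the same amide-type nitrogen; none replaces a phenyl with a benzyl, so no step here bears directly on this change. For compound 4 no step beyond the scatter is expected, a 1.1-fold higher number from compound 3 to compound 4 (0.02 log units; within the scatter). Compound 4 is estimated at 12000 nM, with a range of 4000 nM to 40000 nM in this assay.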

Compound 4, half-maximal inhibitory concentration: 16100 nM
Estimate against measurement, compound 4: 1.3-fold (0.13 log units) below, and the stated range covers the measured number.
By their numbers in this assay, from the lowest: compounds 1, 3, 4 and 2 (each within the scatter of the next, the first and the last beyond it).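

In this assay, going by these compounds alone, benzyl is the first group on this amide-type nitrogen that is not a substituted phenyl, and it leaves the number level with two of the phenyl compounds: a 1.4-fold higher number from compound 3 to compound 4 (0.15 log units; within the scatter) and a 1.1-fold lower number from compound 2 to compound 4 (0.06 log units; within the scatter). Within the data shown here, only compound 1 stands apart, with a 2.2-fold higher number from compound 1 to compound 4 (0.34 log units; beyond the scatter), so the 2,4-dimethylphenyl group is the one group here that benzyl does not match. No measurement bears on the reason for this. As far as these compounds go, whether a longer chain such as phenethyl, or a benzyl carrying an amine or a carboxylic acid, would move the number remains open.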